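The source may hold more compounds than are shown below. What is called first, only, known or untested is meant among the compounds shown, and "the series" means these compounds.

Compound 1, `O=C(CN[C@H]1CCN(S(=O)(=O)Cc2ccccc2)C1)N1CCN(Cc2cccc(Cl)c2)CC1`, gives 8600 nM in a functional assay on K562 cells (Homo sapiens) for cytotoxicity, read by MTT assay, with a stated time of 48 h; a higher number here means a weaker inhibitor, a lower number a stronger inhibitor.
Compound 2, `O=C(CN[C@H]1CCN(S(=O)(=O)Cc2ccccc2)C1)N1CCN(Cc2cccc(F)c2)CC1`, gives 13200 nM in this assay.
Compound 3, `O=C(CN[C@H]1CCN(S(=O)(=O)Cc2ccccc2)C1)N1CCN(Cc2c(Cl)cccc2Cl)CC1`, gives 28400 nM in this assay.

The three share a core and differ only in the group carried on the saturated chain carbon bound to an amine nitrogen in a ring. Compound 1 and compound 2 differ by fluoro in place of chloro on an aromatic carbon, and the step is a 1.5-fold higher number from compound 1 to compound 2 (0.19 log units; within the scatter). Compound 3 carries a different core group, described by 2,6-dichlorophenyl in place of 3-chlorophenyl on a saturated chain carbon bound to an amine nitrogen in a ring, and the step is a 3.3-fold higher number from compound 1 to compound 3 (0.52 log units; beyond the scatter); from compound 2 the step is a 2.2-fold higher number from compound 2 to compound 3 (0.33 log units; beyond the scatter).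

Compound 4, `O=C(CN[C@H]1CCN(S(=O)(=O)Cc2ccccc2)C1)N1CCN(Cc2c(F)cccc2Cl)CC1`, has not been measured in this assay. It differs from compound 3 by fluoro in place of chloro on an aromatic carbon. This is the same kind of change as between compound 1 and compound 2, but the place is not identical: here the change sits ortho to a large group and meta to a chloro group, whereas in compound 2 it sits meta to a large group. Because the earlier step of a 1.5-fold higher number from compound 1 to compound 2 (0.19 log units; within the scatter) stayed within the scatter, compound 4 is expected to show a similarly small step, a 1.2-fold higher number from compound 3 to compound 4 (0.09 log units; within the scatter). Compound 4 is thus estimated at 35000 nM, between 15000 nM and 80000 nM.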

Compound 4, half-maximal inhibitory concentration: 65800 nM
For compound 4 the middle estimate is 1.9-fold (0.27 log units) below the measured one, and the stated range covers the measured number.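

In this assay, fluoro in place of chloro raises the number on both cores, and the two steps do not differ by more than the scatter allows: the same change on two cores in this assay, a 1.5-fold higher number (0.19 log units; within the scatter) from compound 1 to compound 2 and a 2.3-fold higher number (0.36 log units; beyond the scatter) from compound 3 to compound 4, 1.5-fold (0.18 log units) apart, within the scatter of two such steps. The change therefore carries over from the core of compound 1 to the core of compound 3 in direction, even though only the newer step, a 2.3-fold higher number from compound 3 to compound 4 (0.36 log units; beyond the scatter), lies beyond the scatter on its own. This rests on just two pairs, so it shows no general rule, and it cannot say why the 2-chloro-6-fluorobenzyl group of compound 4 gives the highest number here, with a 5.0-fold higher number from compound 2 to compound 4 (0.70 log units; beyond the scatter) and a 7.7-fold higher number from compound 1 to compound 4 (0.88 log units; beyond the scatter).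

Still open, as far as these compounds go, is whether the trend continues to a 2,6-difluorobenzyl group, or what a bromo or methoxy group would do in the place of the chloro. The compounds shown also leave open whether the same change behaves alike once the benzyl on the sulfonyl group is exchanged for a methyl or a longer chain.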